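From benzyloxy to methoxy in a cytotoxic series

The source may hold more compounds than are shown below. What is called first, only, known or untested is meant among the compounds shown, and "the series" means these compounds.

Compound 1 `COc1ccc(-c2cccc(=O)n2-c2cc(OC)c(OC)c(OC)c2)cc1OC` gives 545 nM
Compound 2 `COc1cc(-n2c(-c3ccc([N+](=O)[O-])cc3)cccc2=O)cc(OC)c1OC` gives 201 nM
Compound 3 `COc1ccc(-n2c(-c3cc(OC)c(OC)c(OC)c3)cccc2=O)cc1OCc1ccccc1` gives 25500 nM

All three numbers come from a functional assay on SK-OV-3 cells (Homo sapiens) for cytotoxicity, read by spectrophotometry, with a stated time of 72 h (on this read-out lower numbers stand for stronger inhibition and higher numbers for weaker inhibition), and compound 3 stands highest among them, which makes it the weakest inhibitor of the set. Compound 1 lies nearest to it and compound 2 furthest, and both gaps are beyond the usual scatter.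

Compound 4 `COc1ccc(-n2c(-c3cc(OC)c(OC)c(OC)c3)cccc2=O)cc1OC` has not yet been measured. It departs from compound 3 by one change, (hydrogen in place of phenyl on a saturated chain carbon bound to an oxygen on an aromatic ring), which means hydrogen in place of phenyl on a saturated chain carbon bound to an oxygen on an aromatic ring, or benzyloxy to methoxy.

Within the data shown here, no measured pair shows this change on its own, so any expectation is indirect. Neither of the other two compounds carries a benzyloxy group, and compound 1 at 545 nM and compound 2 at 201 nM both sit far lower than compound 3. A large drop beyond the scatter is therefore expected, and the estimated step is a 51-fold lower number from compound 3 to compound 4 (1.71 log units; beyond the scatter). For compound 4 the estimated value is 500 nM, with an expected range from 60 nM to 4000 nM.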

Compound 4, half-maximal inhibitory concentration: 14300 nM
Beside the measured number, compound 4's estimate is 29-fold (1.46 log units) below it, outside the stated range (above it).
By their numbers in this assay, from the lowest: compound 2; then compound 1; then compounds 4 and 3 (each within the scatter of the next).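

In this assay, among these compounds, the exchange of benzyloxy for methoxy, on a saturated chain carbon bound to an oxygen on an aromatic ring, can now be read directly for the first time, as a 1.8-fold lower number from compound 3 to compound 4 (0.25 log units; within the scatter). The phenyl group that leaves therefore makes no difference beyond the scatter at this place on this core. Without that phenyl group, compound 4 still gives 14300 nM. Nothing available explains why the two compounds stay so close.

Compound 1 and compound 2 differ from compound 3 and compound 4 in more than one place, so they cannot show which structural feature separates their numbers from the higher pair. As far as these compounds go, it also remains open whether a hydroxyl group, an ethoxy group or a longer chain ending in an amine at this same place would leave the number within the scatter or move it beyond, and whether the exchange of benzyloxy for methoxy would prove equally silent on the core of compound 1.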